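From Compound 2 to Compound 3: Amino in Place of Nitro

The source may report more compounds than this note shows. Statements on the series, on what has been measured and on what is new or still open speak of the compounds shown alone.

Compound 1 `O=C(N/N=C\c1ccc(O)cc1)Nc1nnc(COc2ccc3ccccc3c2)o1` and compound 2 `C/C(=N/NC(=O)Nc1nnc(COc2ccc3ccccc3c2)o1)c1ccc([N+](=O)[O-])cc1` share the same core. In a functional assay on the whole organism (strain Swiss albino) with Mus musculus as the target, in the maximal electroshock model, with a stated time of 4 h (on this read-out higher numbers stand for an effect only at larger amounts of compound and lower numbers for an effect already at smaller amounts), compound 1 gives 300 mg/kg, and in this assay compound 2 gives 300 mg/kg; the two values are level within the scatter, so compound 2 stands alongside compound 1 on these numbers. Compound 3 `C/C(=N/NC(=O)Nc1nnc(COc2ccc3ccccc3c2)o1)c1ccc(N)cc1` differs from compound 2 in one place: amino in place of nitro on an aromatic carbon. Within the data shown here, no measured pair shows what this change does here. The step of no change at the digits printed from compound 2 to compound 3 (within the scatter) is expected to be none beyond the scatter. The estimate for compound 3 in this assay is 300 mg/kg, ranging from 100 mg/kg to 600 mg/kg.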

Compound 3, minimum effective dose: 300 mg/kg
Beside the measured number, compound 3's estimate shows no gap at the digits printed, and the stated range covers the measured number.
By their numbers in this assay, from the lowest: compounds 1, 2 and 3 (each within the scatter of the next).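

Amino in place of nitro on the aromatic carbon brings no change at the digits printed from compound 2 to compound 3 (within the scatter) in this assay, giving the first measured single-place pair at this position. The larger exchange on the amide-type nitrogen likewise brings no change at the digits printed from compound 1 to compound 3 (within the scatter) in this read-out. No available evidence accounts for this flat result.

The compounds shown leave open whether another group at this place, such as a carboxylic acid or a methoxy group, would shift the minimum effective dose. They also leave open whether a change elsewhere on the shared core would do so.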